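The source may report more compounds than this note shows. Statements on the series, on what has been measured and on what is new or still open speak of the compounds shown alone.

The compounds measured in a functional assay on SK-OV-3 cells (Homo sapiens) for cytotoxicity, read by MTT assay, with a stated time of 48 h (a higher number here means a weaker inhibitor, a lower number a stronger inhibitor), are: compound 1 `CC(C)COc1ccc2c(Cl)ccnc2c1`, 3190 nM. Compound 2 `CN(C)CCNc1ccnc2cc(OCc3ccccc3)ccc12`, 2350 nM. Compound 3 `CCCCCCOc1ccc2c(Cl)ccnc2c1`, > 10000 nM, which is a limit of the assay and not a number.

Compound 3 thus stands only at a limit in this assay; what is known of it is the limit of > 10000 nM in this assay, at which 1 of the 3 values shown sits. Compound 4 `CCOc1ccc2c(Cl)ccnc2c1` differs from compound 3 by hydrogen in place of butyl on a saturated chain carbon, two bonds along the chain from an oxygen on an aromatic ring. Among the compounds with values here, only one measured step bears on this change, the lengthening of the same chain on the same core: an at least 3.1-fold higher number from compound 1 to compound 3 (0.49 log units; beyond the scatter). Within the data shown here, the change from compound 3 to compound 4 runs the other way along that chain, so a lower number than the limit of compound 3 is expected, though the measured step gives only a floor for how large the move was, and no measured compound carries a chain shorter than that of compound 1. Compound 4 is therefore expected to give about 4000 nM in this assay, within 1500 nM to 12000 nM. The expected step reads an at least 2.5-fold lower number from compound 3 to compound 4 (0.39 log units; beyond the scatter).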

Compound 4, half-maximal inhibitory concentration: 3460 nM
Estimate against measurement, compound 4: 1.2-fold (0.06 log units) above; the measured number falls inside the stated range.
By their numbers in this assay, from the lowest: compounds 2, 1 and 4 (each within the scatter of the next). At a limit, above all of these: compound 3.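

In this assay, hexyl to ethyl gives an at least 2.8-fold lower number from compound 3 to compound 4 (0.46 log units; beyond the scatter), so the chain on the shared core has now been read in both directions, and cutting it back restores a measurable number. Methyl in place of isopropyl, by contrast, stays within the scatter, at a 1.1-fold higher number from compound 1 to compound 4 (0.04 log units; within the scatter), so among these three compounds only the hexyl chain of compound 3 stands apart. The value of compound 3 is a limit of the assay and not a number: the limit of > 10000 nM in this assay, at which 1 of the 4 values shown sits.

Open, going by these compounds, is where between the ethyl chain and the hexyl chain the number starts to climb, which a butyl chain on the same core would help to place. On these data alone, compound 2 differs from the others in more than one place, so what an amine in place of the chlorine does on these simple ethers also stays open.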